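Replacing the bromophenyl amide in a glutathione transferase inhibitor series

The compounds below may be only part of what the source reports. "The series", "measured", "known", "first", "only" and "open" are said of these compounds alone.

Three amides sharing one core have been measured in an assay on isolated protein for inhibition of glutathione S-transferase Mu 2 (Homo sapiens), with a stated time of 10 min; a lower number here means a stronger inhibitor, a higher number a weaker inhibitor: compound 1 `COc1ccccc1NC(=O)CCC(=O)OCCCCCCSc1ccc([N+](=O)[O-])c2nonc12` gives 280 nM, compound 2 `O=C(CCC(=O)OCCCCCCSc1ccc([N+](=O)[O-])c2nonc12)Nc1cccc(Cl)c1` gives 1100 nM, and compound 3 `O=C(CCC(=O)OCCCCCCSc1ccc([N+](=O)[O-])c2nonc12)Nc1ccc(Br)cc1` gives 32000 nM, the highest of the three numbers. The steps of a 110-fold higher number from compound 1 to compound 3 (2.06 log units; beyond the scatter) and a 29-fold higher number from compound 2 to compound 3 (1.46 log units; beyond the scatter) place compound 3 well beyond the scatter from both others. Compound 4 `CN(C)CCNC(=O)CCC(=O)OCCCCCCSc1ccc([N+](=O)[O-])c2nonc12` differs from compound 3 in one place: 2-(dimethylamino)ethyl in place of 4-bromophenyl on an amide-type nitrogen. Going by the values given here, none of the measured steps bears directly on this change, since each of them exchanges one aryl group for another; they only show how widely this position can move the number. For compound 4 the step of a 1.3-fold lower number from compound 3 to compound 4 (0.11 log units; within the scatter) is therefore expected to stay within the scatter, with a wide range, and its value is estimated at 25000 nM (between 4000 nM and 150000 nM).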

Compound 4, half-maximal inhibitory concentration: 160 nM
Beside the measured number, compound 4's estimate is 160-fold (2.19 log units) above it; measured number outside the range, below it.
By their numbers in this assay, from the lowest: compounds 4 and 1 (each within the scatter of the next); then compound 2; then compound 3.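

In this assay the amide-type nitrogen does not need an aromatic ring: 2-(dimethylamino)ethyl, which has no ring, gives a 200-fold lower number from compound 3 to compound 4 (2.30 log units; beyond the scatter) and a 6.9-fold lower number from compound 2 to compound 4 (0.84 log units; beyond the scatter), while a 1.8-fold lower number from compound 1 to compound 4 (0.24 log units; within the scatter) stays level with the 2-methoxyphenyl amide. The position therefore accepts an open chain as well as an aryl group. Nothing available explains these steps.

Whether the dimethylamino nitrogen matters remains open, as the compounds shown do not separate it from the chain carrying it. A plain butyl group, a carboxylic acid or a longer chain ending in dimethylamino could settle this.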